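The source may report more compounds than this note shows. Statements on the series, on what has been measured and on what is new or still open speak of the compounds shown alone.

Compound 1 `Cc1cccc(C(=O)c2ccn(-c3ccc4c(c3)B(O)OC4)c2)c1`: in an ADME assay on L929 cells (Mus musculus) for cytotoxicity, read by resazurin assay, with a stated time of 72 h (a lower number here means a stronger inhibitor, a higher number a weaker inhibitor), compound 1 gives > 10 ug/mL, a limit of the assay.
Compound 2 `Cc1ccccc1C(=O)c1ccn(-c2ccc3c(c2)B(O)OC3)c1`: in this assay compound 2 gives > 10 ug/mL, also a limit.
Compound 3 `COc1ccc(C(=O)c2ccn(-c3ccc4c(c3)B(O)OC4)c2)cc1`: in this assay compound 3 gives > 10 ug/mL, again a limit.

Compound 3 therefore stands only at the limit, as do the other two values, all sitting at the limit of > 10 ug/mL in this assay, at which 3 of the 3 values shown sit. The measured steps a step that the two limits leave unreadable from compound 1 to compound 2, a step that the two limits leave unreadable from compound 1 to compound 3 and a step that the two limits leave unreadable from compound 2 to compound 3 cannot be read in size, so they give no scale for the next change. The step to compound 4 `CCCCCC(=O)c1ccn(-c2ccc3c(c2)B(O)OC3)c1` replaces (pentyl in place of 4-methoxyphenyl on a carbonyl carbon). With every comparable value at the limit, no readable step bears on it, and the expected step that the limit leaves unreadable from compound 3 to compound 4 is none beyond the scatter. Compound 4 is estimated at 15 ug/mL in this assay, within 5 ug/mL to 40 ug/mL.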

Compound 4, half-maximal inhibitory concentration: > 10 ug/mL
Compound 4: only a limit was reported; the forecaster's own chance of this, stated with the estimate: 70%; the middle value does not contradict the limit.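

The steps to compound 4 from compound 1, compound 2 and compound 3 cannot be read in size, as all these values are limits: the limit of > 10 ug/mL in this assay, at which 4 of the 4 values shown sit. From the compounds shown here alone, whether pentyl, 4-methoxyphenyl, 2-methylphenyl and 3-methylphenyl differ at all in this assay stays open.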